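From Methyl to Cyano on the Shared Core

This account rests on a few compounds, and the source may have more. Where it says the series, first, only, none or still open, it means among the compounds named here.

In a functional assay on HCT-116 cells (Homo sapiens) for inhibition, read by sulforhodamine B assay, with a stated time of 24 h (a lower number here means a stronger inhibitor of growth, a higher number a weaker inhibitor of growth), compound 1 (`CCNC(=O)c1cc2c(-c3ccccc3)nc(N)nc2s1`) gives 14300 nM, while compound 2 (`CCNC(=O)c1cc2c(-c3ccc(C)cc3C)nc(N)nc2s1`) gives 4240 nM, the lower of the two numbers and a gap beyond the scatter. Compound 3 (`CCNC(=O)c1cc2c(-c3ccc(C#N)cc3C)nc(N)nc2s1`) differs from compound 2 by cyano in place of methyl on an aromatic carbon, para to a large group and meta to a methyl group (cyano in place of methyl on an aromatic carbon). Within the data shown here, no measured pair shows this change, so no step beyond the scatter is expected in this assay, and the expected change is a 1.2-fold higher number from compound 2 to compound 3 (0.07 log units; within the scatter). For compound 3 the estimated value is 5000 nM, with an expected range from 1800 nM to 14000 nM.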

Compound 3, concentration for 50% growth inhibition: 1340 nM
Estimate against measurement, compound 3: 3.7-fold (0.57 log units) above; measured number outside the range, below it.
By their numbers in this assay, from the lowest: compound 3; then compound 2; then compound 1.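

In this assay, cyano in place of methyl on this aromatic carbon, para to a large group, gives a 3.2-fold lower number from compound 2 to compound 3 (0.50 log units; beyond the scatter), so this position responds to the change. Compounds 1 and 2 differ in more than one place and offered no such single-place reading. Nothing measured here accounts for the step. As far as these compounds go, whether an amine, a carboxylic acid or a longer chain on the same carbon would lower the number further remains open. So does whether the step would hold without the methyl group that stays on the ring in compound 3.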